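A few compounds are considered here, and "the series" means these few. Any claim that something is new, unique, unknown or untested is made for them only; others in the source may bear on it.

Series notes, values in a functional assay on HepG2 cells (Homo sapiens) for cytotoxicity, read by MTT assay, with a stated time of 48 h; a lower number here means a stronger inhibitor, a higher number a weaker inhibitor:

- compound 1 `Cc1cc(Cl)cc2c(=O)cc(-c3ccccc3Cl)oc12`: "not determined" (no result reported)
- compound 2 `CN(C)Cc1cc(Cl)cc2c(=O)cc(-c3ccccc3Cl)oc12`: 1870 nM

Among the measured compounds shown here, compound 2, at 1870 nM, gives the only number so far, so it cannot be ranked as strong or weak against a neighbour. Compound 1 has no result in this assay, and its entry of "not determined" (no result reported) provides no comparison for compound 2.

The next compound to be tested is compound 3 `O=c1cc(-c2ccccc2Cl)oc2c(Cn3ccnc3)cc(Cl)cc12`. It keeps the shared core of compound 2 and changes only the group on the saturated chain carbon bound to an aromatic carbon, with 1H-imidazol-1-yl in place of dimethylamino on a saturated chain carbon bound to an aromatic carbon.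

For the measured compounds named here, no measured pair shows what this exchange does, so the size of the step cannot be drawn from precedent. The working expectation in this assay is therefore no shift beyond the scatter, with only a slight lean towards a weaker compound, and the range is kept wide. The expected change is a 1.3-fold higher number from compound 2 to compound 3 (0.13 log units; within the scatter). For compound 3 the estimated value is 2500 nM, with an expected range of 800 nM to 8000 nM.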

Compound 3, half-maximal inhibitory concentration: 3270 nM
Estimate against measurement, compound 3: 1.3-fold (0.12 log units) below; the measured number falls inside the stated range.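

In this assay, among the compounds shown here, 1H-imidazol-1-yl in place of dimethylamino on a saturated chain carbon bound to an aromatic carbon gives a 1.7-fold higher number from compound 2 to compound 3 (0.24 log units; within the scatter), which is the first step that can be read at this position. On this single pair, an open dimethylamino group and a five-membered aromatic ring with 2 hetero atoms cannot be told apart in this assay, so the ring and the larger group that enter here leave the read-out within the usual scatter of repeated measurements. Nothing at hand accounts for this result, and the pair alone gives no ground for an explanation.

Steps to compound 1 cannot be read, so the series does not yet show how the read-out responds when this chain carbon carries no nitrogen group at all. For the compounds shown here, also open is whether a morpholine ring, a primary amine or a carboxylic acid on the same chain carbon would separate from compound 2 in this assay by more than the scatter, or whether this position stays as undiscriminating as the one pair suggests.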